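The source may hold more compounds than are shown below. What is called first, only, known or untested is meant among the compounds shown, and "the series" means these compounds.

Of the compounds shown here, three have been measured in an assay on isolated protein for inhibition of lysosomal Pro-X carboxypeptidase (Mus musculus), read by fluorescence, with a stated time of 30 min (on this read-out lower numbers stand for stronger inhibition and higher numbers for weaker inhibition), and compound 3, whose structure is `COC(=O)N[C@H]1CC[C@H](Nc2cc(N[C@@H](C)c3ccc(Cl)cc3)ncn2)CC1`, gives 26 nM, the lowest of the three numbers. Going by the values given here, compound 2, with structure `C[C@H](Nc1cc(N[C@H]2CC[C@H](c3ccccc3)CC2)ncn1)c1ccc(Cl)cc1`, gives 75 nM, and the step of a 2.9-fold lower number from compound 2 to compound 3 (0.46 log units; beyond the scatter) marks the only change at the saturated ring carbon that has been tested. Compound 1, with structure `Clc1cc2nc([C@@H]3CCCN3c3cc(N4CCN(Cc5ccccc5)CC4)ncn3)[nH]c2cc1Cl`, sits furthest away and gives 413 nM.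

Compound 4, with structure `C[C@H](Nc1cc(N[C@H]2CC[C@H](NS(C)(=O)=O)CC2)ncn1)c1ccc(Cl)cc1`, has not yet been measured. It differs from compound 3 in one place: methylsulfonyl in place of methoxycarbonyl on an amine nitrogen. The two groups that change places match each other in heavy-atom count and in the number of hydrogen-bond acceptors, and neither carries a donor or a charge. Among the compounds with values here, no measured step covers an exchange of this kind, so the expectation rests on the position itself: the step from compound 2 to compound 3 shows that the number at this saturated ring carbon can move by a modest amount when the group is exchanged, but whether a sulfonyl is read differently from a carbamate here is unknown.

On that basis the step from compound 3 to compound 4 is expected to be small, roughly a 1.3-fold higher number from compound 3 to compound 4 (0.13 log units; within the scatter), with no direction claimed. Compound 4 is therefore estimated to give 35 nM in this assay, with a range from 12 nM to 100 nM.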

Compound 4, half-maximal inhibitory concentration: 105 nM
Beside the measured number, compound 4's estimate is 3.0-fold (0.48 log units) below it; the whole stated range lies below it.
By their numbers in this assay, from the lowest: compound 3; then compounds 2 and 4 (each within the scatter of the next); then compound 1.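

In this assay, the nitrogen on the saturated ring carbon turns out to be sensitive to which group it carries: methylsulfonyl in place of methoxycarbonyl gives a 4.0-fold higher number from compound 3 to compound 4 (0.61 log units; beyond the scatter), even though the two groups match in heavy-atom count and in hydrogen-bond donors and acceptors. The earlier compounds shown here showed only that replacing phenyl on the ring carbon could move the number, whereas this pair shows that the group on the nitrogen matters too, and that such counts alone do not settle the outcome here. Methanesulfonamido in place of phenyl, by contrast, gives a 1.4-fold higher number from compound 2 to compound 4 (0.15 log units; within the scatter), so the step seen with (methoxycarbonyl)amino does not carry over to every group attached through nitrogen at this carbon, and nothing available here explains the difference between the two groups.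

As far as these compounds go, it remains open whether an acetyl group or a urea on the same nitrogen would read like methoxycarbonyl or like methylsulfonyl, and what a free amine at the ring carbon would give. A longer chain on the sulfonyl or on the carbamate oxygen is also an open question.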